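A few compounds are considered here, and "the series" means these few. Any claim that something is new, unique, unknown or untested is made for them only; others in the source may bear on it.

Compound 1, `COc1ccc(NC(=O)Nc2cc(C)nc3ccccc23)cc1`, was tested in an ADME assay on BJ cells (Homo sapiens) for cytotoxicity, with a stated time of 72 h; a lower number here means that less compound is needed, a higher number that more compound is needed for the effect. Compound 1 gives > 25000 nM in this assay, which is a limit of the assay rather than a number. Compound 2, `COc1ccc(NC(=O)Nc2cc(C)nc3ccccc23)cc1F`, gives 26000 nM in this assay. Compound 3, `Cc1cc(NC(=O)Nc2cccc(C(N)=O)c2)c2ccccc2n1`, gives > 25000 nM in this assay, again a limit. Two of the three values thus sit at the limit of > 25000 nM in this assay, at which 2 of the 3 values shown sit, so compound 1 stands at the edge of what this assay reports, with no measured number of its own. For the measured compounds named here, the only step between measured compounds that differ in a single place, a step that the limit leaves unreadable from compound 1 to compound 2, has a size that the limit leaves unreadable.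

Compound 4, `Cc1cc(NC(=O)Nc2ccc(F)cc2)c2ccccc2n1`, has not yet been measured in this assay. It differs from compound 1 in one place: fluoro in place of methoxy on an aromatic carbon. Going by the values given here, no measured step shows what this change does, and the one available step gives no size. Because the limit of > 25000 nM in this assay, at which 2 of the 3 values shown sit, holds two of the three values, little movement away from it is expected. For compound 4 the estimated value is 30000 nM, with a range from 15000 nM to 80000 nM. The expected step is a step that the limit leaves unreadable from compound 1 to compound 4, meaning nothing beyond the usual scatter.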

Compound 4, half-maximal effective concentration: > 25000 nM
Compound 4: only a limit was reported (the forecaster's own chance of this, stated with the estimate: 70%); the middle value does not contradict the limit.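

No step can be read between compound 1 and compound 4, since each is reported in this assay only as a limit: the limit of > 25000 nM in this assay, at which 3 of the 4 values shown sit.

The compounds shown leave open whether fluoro in place of methoxy changes the concentration needed for the effect at all.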